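This account rests on a few compounds, and the source may have more. Where it says the series, first, only, none or still open, it means among the compounds named here.

Notes on the series, read in a functional assay on A549 cells (Homo sapiens) for antiproliferative activity, read by sulforhodamine B assay, with a stated time of 48 h; a higher number here means a weaker inhibitor, a lower number a stronger inhibitor. For the measured compounds named here, compound 1 (`COc1ccc(/C=C/C(=O)c2ccccc2-c2ccc(F)cc2)cc1O`) gives 430 nM, the highest of the three numbers so far. Compound 3 (`CN(C)c1ccc(/C=C/C(=O)c2ccccc2-c2ccc(F)cc2)cc1`) gives 110 nM, and compound 2 (`COc1ccc(/C=C/C(=O)c2ccccc2-c2ccc(F)cc2)cc1B(O)O`) gives 74 nM.

Compound 4 (`COc1ccc(/C=C/C(=O)c2ccccc2-c2cccc(F)c2)cc1O`) has the same atoms as compound 1, joined differently: 3-fluorophenyl in place of 4-fluorophenyl on an aromatic carbon. The change sits on an aromatic carbon, ortho to a large group. Going by the values given here, all three measured compounds carry 4-fluorophenyl, so no measured step tests this change directly. Among the compounds with values here, the one measured step, a 5.8-fold lower number from compound 1 to compound 2 (0.76 log units; beyond the scatter), lies at a different place and gives neither size nor direction for the move to 3-fluorophenyl. The estimate therefore rests on compound 1 at 430 nM, with a wide range to cover the lack of direct evidence. In this assay the expected step is a 1.1-fold higher number from compound 1 to compound 4 (0.05 log units; within the scatter), with no change beyond the scatter and no firm direction expected. For compound 4 the estimated value is 480 nM, with an expected range of 170 nM to 1300 nM.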

Compound 4, half-maximal inhibitory concentration: 180 nM
Estimate against measurement, compound 4: 2.7-fold (0.43 log units) above; the measured number falls inside the stated range.
By their numbers in this assay, from the lowest: compounds 2, 3 and 4 (each within the scatter of the next, the first and the last beyond it); then compound 1.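

In this assay, 3-fluorophenyl in place of 4-fluorophenyl on the core of compound 1 gives a 2.4-fold lower number from compound 1 to compound 4 (0.38 log units; beyond the scatter). For the compounds shown here, this is the first measured evidence that this position is sensitive to where the fluorine stands on the ring, even though the atoms are unchanged; the earlier compounds all carry 4-fluorophenyl and differ only elsewhere. Nothing available accounts for the step, so it stands as an observation on this one pair.

On these data alone, whether the same change would lower the number on compound 2 or compound 3 remains open, since this step has been read only on the core of compound 1. Also open, as far as these compounds go, is how this position responds to a plain phenyl with no fluorine, or to chlorine in place of the fluorine.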